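Stereochemical Inversion in a Thiazolylmethylamine Urea Series

The source may report more compounds than this note shows. Statements on the series, on what has been measured and on what is new or still open speak of the compounds shown alone.

Compound 1 `NCc1ncc(C2=CCC(N(CCN3CCCC3)C(=O)Nc3ccc(F)c(Cl)c3)CC2)s1`: 88%
Compound 2 `C[C@@H]1CN(CCCN(C(=O)Nc2cc(Cl)nc(Cl)c2)[C@H]2CC[C@@]3(c4cnc(CN)s4)C[C@@H]23)[C@@H](C)CN1`: 20%

In a functional assay on the whole organism with Mus musculus as the target, at a dose of 30 mg/kg by the oral route (a lower number here means less inhibition, a higher number more inhibition at the dose given (going by the name of the read-out)), compound 1 gives 88%, whereas compound 2 gives 20%, the lower of the two numbers and separated from compound 1 by a gap beyond the scatter. Compound 3 `C[C@@H]1CN(CCCN(C(=O)Nc2cc(Cl)nc(Cl)c2)[C@H]2CC[C@]3(c4cnc(CN)s4)C[C@H]23)[C@@H](C)CN1` awaits measurement in this assay. Among the compounds with values here, it differs from compound 2 as follows: the two compounds have the same atoms and bonds and differ only in configuration as drawn: 2 of 5 stereo elements differ; a stereocentre at a saturated ring carbon is drawn R in compound 2 and S in compound 3; a stereocentre at a saturated ring carbon is drawn R in compound 2 and S in compound 3 No measured pair shows what such an inversion does here, so the direction is open. The step expected is a number 15 percentage points higher from compound 2 to compound 3 (beyond the scatter), of uncertain sign. Compound 3 is estimated at 35%, within 5% to 85%.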

Compound 3, a percentage reported as inhibition, in the whole organism at one dose (the size of the read-out at that dose, not a potency): 16%
Compound 3: middle estimate off by 19 percentage points, on the high side, within the range that was stated.
By their numbers in this assay, from the lowest: compounds 3 and 2 (each within the scatter of the next); then compound 1.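

In this assay, within the data shown here, the inversion of the two saturated ring stereocentres gives a number 4 percentage points lower from compound 2 to compound 3 (within the scatter), so this pair supplies the first reading of such a change and shows no separation at this dose. The pair can be read as a clean comparison of configuration because nothing else separates the structures: the fact that compounds 2 and 3 differ only in the configuration as drawn

The compounds shown leave open what inverting either stereocentre alone would do, since both change together here. They also leave open whether the inversion would remain within the scatter with a carboxylic acid in place of the primary amine.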